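The compounds below may be only part of what the source reports. "The series", "measured", "known", "first", "only" and "open" are said of these compounds alone.

Working notes on a short series of protected nucleoside analogues sharing one core, scored in a functional assay on HEL cells (Homo sapiens) for cytotoxicity, read by microscopy; a higher number here means that more compound is tolerated, a lower number that less compound is tolerated. Compound 1 `Cc1cn([C@@H]2O[C@H](CO[Si](C)(C)C(C)(C)C)[C@@]3(OS(=O)(=O)C=C3NCCC(=O)O)[C@H]2O[Si](C)(C)C(C)(C)C)c(=O)n(C)c1=O` carries a carboxymethyl on the saturated chain carbon bound to the amine nitrogen; in this assay compound 1 gives 80000 nM. Compound 2 `COC(=O)CNC1=CS(=O)(=O)O[C@@]12[C@@H](CO[Si](C)(C)C(C)(C)C)O[C@@H](n1cc(C)c(=O)n(C)c1=O)[C@@H]2O[Si](C)(C)C(C)(C)C` is the methyl ester analogue; in this assay compound 2 reaches only a limit, >= 400000 nM. Compound 3 `Cc1cn([C@@H]2O[C@H](CO[Si](C)(C)C(C)(C)C)[C@@]3(OS(=O)(=O)C=C3NCC(=O)OCc3ccccc3)[C@H]2O[Si](C)(C)C(C)(C)C)c(=O)n(C)c1=O` is the benzyl ester analogue; in this assay compound 3 likewise reaches only a limit, >= 400000 nM. Both esters thus sit at the limit of >= 400000 nM in this assay, at which 2 of the 3 values shown sit, whereas the acid compound 1 sits beyond the scatter below them: an at least 5.0-fold higher number from compound 1 to compound 2 (0.69 log units; beyond the scatter) and an at least 5.0-fold higher number from compound 1 to compound 3 (0.69 log units; beyond the scatter). Between the two esters the step that the two limits leave unreadable from compound 2 to compound 3 cannot be read, as both are limits.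

Compound 4 `Cc1cn([C@@H]2O[C@H](CO[Si](C)(C)C(C)(C)C)[C@@]3(OS(=O)(=O)C=C3NCC(=O)O)[C@H]2O[Si](C)(C)C(C)(C)C)c(=O)n(C)c1=O` is the free acid of compound 3: hydrogen in place of benzyl on an oxygen next to a carbonyl group. This reverses the ester direction that, going from compound 1 to compound 3, produced the rise. Compound 4 is expected to leave the limit and move toward the acid compound 1, a step of an at least 4.0-fold lower number from compound 3 to compound 4 (0.60 log units; beyond the scatter). For compound 4 the estimated value is 100000 nM, with a range from 30000 nM to 400000 nM.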

Compound 4, minimum cytotoxic concentration: 300000 nM
Beside the measured number, compound 4's estimate is 3.0-fold (0.48 log units) below it; measured number inside the range.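

In this assay, replacing the ester with the free acid gives only an at least 1.3-fold lower number from compound 3 to compound 4 (0.12 log units; that floor lies within the scatter) and an at least 1.3-fold lower number from compound 2 to compound 4 (0.12 log units; that floor lies within the scatter), so a real fall on losing the ester is not shown at this position. The two acids do part: a 3.8-fold higher number from compound 1 to compound 4 (0.57 log units; beyond the scatter), so a free carboxy group alone does not bring the low number seen with the longer chain of compound 1. The two ester steps remain floors because the esters stand at a limit: the limit of >= 400000 nM in this assay, at which 2 of the 4 values shown sit.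

Still open, going by these compounds, is whether an ester on the longer chain of compound 1 would return to that limit, which would separate the effect of chain length from that of the free acid. Also open, on these data alone, is how a still longer chain ending in a carboxylic acid, or a chain ending in an amine or an amide, would read.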